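The source may hold more compounds than are shown below. What is called first, only, known or untested is meant among the compounds shown, and "the series" means these compounds.

Measured compounds in a functional assay on brain for inhibition of Norepinephrine transporter (Rattus norvegicus); a lower number here means a stronger inhibitor, a higher number a weaker inhibitor:
- compound 1 `CN(C)C/C=C(/c1ccccc1)c1cccnc1`: 27000 nM
- compound 2 `CN(C)C/C=C(/c1ccc(Cl)cc1)c1cccnc1`: 10000 nM
- compound 3 `COc1ccc(/C(=C/CN(C)C)c2cccnc2)cc1`: > 28000 nM, a limit of the assay, not a number

Compound 1 stands highest of the two numbers shown, with compound 2 nearest at a 2.7-fold lower number from compound 1 to compound 2 (0.43 log units; beyond the scatter). Compound 3 sits at the limit of > 28000 nM in this assay, at which 1 of the 3 values shown sits, and gives no number, so its step from compound 1 is only a floor: an at least 1.0-fold higher number from compound 1 to compound 3 (0.01 log units; that floor lies within the scatter). From compound 2 to compound 3 the step is an at least 2.8-fold higher number from compound 2 to compound 3 (0.44 log units; beyond the scatter).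

Compound 4 `CN(C)C/C=C(\c1cccnc1)c1cccc(F)c1` is not yet measured. It differs from compound 1 by fluoro in place of hydrogen on an aromatic carbon. Going by the values given here, the steps that bear on it are both single substitutions on the same aromatic carbon of the core of compound 1: chloro in place of hydrogen gave a 2.7-fold lower number from compound 1 to compound 2 (0.43 log units; beyond the scatter), methoxy in place of hydrogen gave an at least 1.0-fold higher number from compound 1 to compound 3 (0.01 log units; that floor lies within the scatter). Fluoro is a halogen like chloro, but smaller; a step in the direction of compound 2 is possible, though no fluoro analogue is among the measured compounds to anchor it.

The expected step for compound 4 is therefore a 1.4-fold lower number from compound 1 to compound 4 (0.13 log units; within the scatter), within or just beyond the scatter, toward a lower number. Compound 4 is estimated at 20000 nM in this assay, with a range from 8000 nM to 45000 nM.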

Compound 4, half-maximal inhibitory concentration: 2200 nM
For compound 4 the middle estimate is 9.1-fold (0.96 log units) above the measured one; measured number below the stated range.
By their numbers in this assay, from the lowest: compound 4; then compound 2; then compound 1. At a limit, above all of these: compound 3.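

In this assay fluoro in place of hydrogen on an aromatic carbon, meta to a large group, gives a 12-fold lower number from compound 1 to compound 4 (1.09 log units; beyond the scatter) on the core of compound 1, so a change of one heavy atom at this place is enough for a large step. Going by these compounds alone, this is the first step to reach that size, and it exceeds a 2.7-fold lower number from compound 1 to compound 2 (0.43 log units; beyond the scatter) from the same parent, whereas the methoxy step from compound 1 has only a floor within the scatter; compound 2 and compound 4 differ in more than one place, so no step between them can be read. Nothing at hand accounts for the size of this step.

The compounds shown leave open whether the step belongs to fluoro itself or to the carbon that carries it: no other group appears on that carbon, and no fluoro appears on another carbon of that ring. Chloro, methoxy, nitrile or trifluoromethyl on that same carbon would separate these two readings, as would fluoro on the other carbons of that ring.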